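The source may hold more compounds than are shown below. What is called first, only, known or untested is meant among the compounds shown, and "the series" means these compounds.

In a functional assay on HEp-2 cells (Homo sapiens) for inhibition, read by sulforhodamine B assay, with a stated time of 48 h, tested at 100 uM (a higher number here means more inhibition of growth at the concentration tested, a lower number less inhibition of growth), compound 1 `Cc1ccc2occ(C3N=C(c4ccccc4)SS3)c(=O)c2c1` gives 43%, compound 2 `O=c1c(C2N=C(c3ccccc3)SS2)coc2ccc(F)cc12` gives 51% and compound 3 `O=c1c(C2N=C(c3ccccc3)SS2)coc2ccccc12` gives 48%. Compound 2 has the top number of the three, but the gaps around it are small: a number 3 percentage points lower from compound 2 to compound 3 (within the scatter) and a number 8 percentage points higher from compound 1 to compound 2 (within the scatter), both within the scatter, so the three compounds cannot be separated on these numbers.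

Compound 4 `O=c1c(C2N=C(c3ccccc3)SS2)coc2cc(Cl)c(F)cc12` has not been measured. It differs from compound 2 in one place: chloro in place of hydrogen on an aromatic carbon. The three measured steps all also exchange a substituent on an aromatic carbon of the same fused ring system: a number 8 percentage points higher from compound 1 to compound 2 (within the scatter), a number 5 percentage points higher from compound 1 to compound 3 (within the scatter) and a number 3 percentage points lower from compound 2 to compound 3 (within the scatter). Every one of them stays within the scatter. On this basis no step beyond the scatter is expected in this assay, in either direction, and the expected step from compound 2 is a number 1 percentage points lower from compound 2 to compound 4 (within the scatter). Compound 4 is therefore estimated at 50%, with a range from 35% to 65%.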

Compound 4, percent growth inhibition at one concentration: 52%
The estimate for compound 4 lay 2 percentage points below the measured number; measured number inside the range.
By their numbers in this assay, from the lowest: compounds 1, 3, 2 and 4 (each within the scatter of the next).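

In this assay the step for chloro in place of hydrogen is a number 1 percentage points higher from compound 2 to compound 4 (within the scatter) and so stays within the scatter. The earlier steps shown here only exchanged the group on a single aromatic carbon, the one that carries the fluoro group in compound 2, whereas compound 4 keeps that fluoro group and adds a substituent on a second aromatic carbon, ortho to the fluoro group. This second carbon therefore carries chloro with no step beyond the scatter in growth inhibition at the single concentration tested, and no measurement shown here speaks to what lies behind this.

On these data alone, whether chloro would give the same number without the neighbouring fluoro group remains open. So does whether an amine, a carboxylic acid or a longer chain on this carbon would take the number beyond the scatter.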